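The source may report more compounds than this note shows. Statements on the series, on what has been measured and on what is new or still open speak of the compounds shown alone.

Measured compounds:
- compound 1 `c1ccc(C2Cc3nccn3C2)cc1`: 1.9; 2.2 (2 entries)
- compound 2 `FC(F)Oc1ccccc1C1Cc2nccn2C1`: 2.3
- compound 3 `COc1ccc(C2Cc3nccn3C2)cc1`: 2

All three share a core and differ only in the aryl substituent. In a physicochemical assay for lipophilicity, at pH 7.4 (a higher number here means a more lipophilic compound, a lower number a more polar compound), compound 2 gives 2.3, and compound 3 gives 2, a gap that lies within the scatter of the method, so the two cannot be ordered. Compound 1 has two entries, (the several entries of compound 1 in this assay, 1.9; 2.2 (2 entries)), which span a similar width and illustrate the spread to be expected from repeats. Among the measured compounds shown here, no pair of measured compounds differs in a single place, so no measured step is available for this series.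

Compound 4 `N#Cc1ccccc1C1Cc2nccn2C1` has not yet been measured in this assay. It differs from compound 2 as follows: cyano in place of difluoromethoxy on an aromatic carbon. For the measured compounds named here, with no measured step to lean on, the expectation rests on the structural change alone. A step beyond the scatter is expected, downward: the estimated step of a number 0.90 log units lower from compound 2 to compound 4 (beyond the scatter). Compound 4 is therefore estimated at 1.4, with a range from 0.9 to 1.9.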

Compound 4, distribution coefficient: 1.3
Compound 4: the middle estimate sits 0.10 log units above what was measured; low and high end bracket the measured number.
By their numbers in this assay, from the lowest: compound 4; then compounds 3 and 2 (each within the scatter of the next).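

Among the compounds shown here, the first measured step comes from cyano in place of difluoromethoxy on an aromatic carbon, ortho to a group of 8 heavy atoms, and in this assay it reads a number 1.00 log units lower from compound 2 to compound 4 (beyond the scatter) for this single pair. The change removes heavy atoms but leaves the counted hydrogen-bond donors and acceptors and the net charge as they were, so those counts alone do not account for the move. The step is also wider than the spread between repeat measurements, which is the only direct check on reproducibility here: the several entries of compound 1 in this assay, 1.9; 2.2 (2 entries)

As far as these compounds go, whether a step of this size carries over to another place on the aromatic ring remains open. So does what an amine, a carboxylic acid or a longer chain would give at this position.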